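The source may report more compounds than this note shows. Statements on the series, on what has been measured and on what is new or still open speak of the compounds shown alone.

Working notes on the series, read in a functional assay on MDA-MB-231 cells (Homo sapiens) for antiproliferative activity, read by MTT assay, with a stated time of 72 h; on this read-out lower numbers stand for stronger inhibition and higher numbers for weaker inhibition. The unsubstituted member is compound 1 (`COc1cc(CCc2ccccc2)cc(OC)c1O`). Compound 1 gives > 25000 nM, which is a limit and not a number. Its bromo analogue is compound 2 (`COc1cc(CCc2ccc(Br)cc2)cc(OC)c1O`). Compound 2 gives > 25000 nM, again a limit. Compound 2 therefore has no numerical standing in the series, and the record so far is the limit of > 25000 nM in this assay, at which 2 of the 2 values shown sit.

The next change leads to compound 3 (`COc1cc(CCc2ccc(Cl)cc2)cc(OC)c1O`): chloro in place of bromo on an aromatic carbon. In words, this is chloro in place of bromo on an aromatic carbon, para to a large group. For the measured compounds named here, the one measured step that bears on it is bromo in place of hydrogen, a step that the two limits leave unreadable from compound 1 to compound 2. That step gives no size to carry over, so no step beyond the scatter is expected in this assay, and a further limit is the most likely report. The expected change is a step that the limit leaves unreadable from compound 2 to compound 3. For compound 3 the estimated value is 30000 nM, with an expected range of 15000 nM to 60000 nM.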

Compound 3, half-maximal inhibitory concentration: > 25000 nM
Compound 3 gave a limit, no number (the forecaster's own chance of this, stated with the estimate: 85%); the middle value does not contradict the limit.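

For the compounds shown here, compound 3 also gives only a limit, so no step among compound 1, compound 2 and compound 3 can be read in this assay. The compounds shown leave open how these three members rank against one another and whether any change to the shared core yields a numerical value, the record so far being: the limit of > 25000 nM in this assay, at which 3 of the 3 values shown sit.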